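Replacing an Aryl Group with Propyl

The source may hold more compounds than are shown below. What is called first, only, known or untested is meant among the compounds shown, and "the series" means these compounds.

Measured in a functional assay on A549 cells (Homo sapiens) for inhibition, read by MTT assay, with a stated time of 48 h; a lower number here means a stronger inhibitor, a higher number a weaker inhibitor:
- Compound 1 `Oc1ccc(C(c2c[nH]c3ccc(Br)cc23)c2c[nH]c3ccc(Br)cc23)cc1` gives 9000 nM
- Compound 2 `COc1ccc(C(c2c[nH]c3ccc(Br)cc23)c2c[nH]c3ccc(Br)cc23)cc1OC` gives 12000 nM
- Compound 3 `Clc1ccc(C(c2c[nH]c3ccc(Br)cc23)c2c[nH]c3ccc(Br)cc23)cc1` gives 8500 nM

Compound 3 stands level with the other two compounds. The steps reaching it are a 1.1-fold lower number from compound 1 to compound 3 (0.02 log units; within the scatter) and a 1.4-fold lower number from compound 2 to compound 3 (0.15 log units; within the scatter), both within the scatter. Compound 4 `CCCC(c1c[nH]c2ccc(Br)cc12)c1c[nH]c2ccc(Br)cc12` carries propyl in place of 4-chlorophenyl on a saturated chain carbon bound to two aromatic carbons. The nearest evidence is these steps and a 1.3-fold higher number from compound 1 to compound 2 (0.12 log units; within the scatter), also within the scatter. All of them swap one substituted phenyl for another, and none removes the ring, so the guide is weak. No step beyond the scatter is expected in this assay. The estimate means a 1.2-fold higher number from compound 3 to compound 4 (0.07 log units; within the scatter). Compound 4 is expected at 10000 nM, with an estimated range of 4000 nM to 25000 nM.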

Compound 4, half-maximal inhibitory concentration: 6500 nM
For compound 4 the middle estimate is 1.5-fold (0.19 log units) above the measured one; low and high end bracket the measured number.
By their numbers in this assay, from the lowest: compounds 4, 3, 1 and 2 (each within the scatter of the next).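

In this assay the ring on the saturated chain carbon bound to two aromatic carbons can be lost without a step beyond the scatter: propyl gives a 1.3-fold lower number from compound 3 to compound 4 (0.12 log units; within the scatter) and also a 1.4-fold lower number from compound 1 to compound 4 (0.14 log units; within the scatter) and a 1.8-fold lower number from compound 2 to compound 4 (0.27 log units; within the scatter). The earlier compounds shown here varied only the substituted phenyl, whereas compound 4 shows that this position tolerates a group with no ring at all. Nothing measured here accounts for this result. The compounds shown leave open whether an amine, a carboxylic acid or a longer chain at this place would move the number beyond the scatter.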